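The compounds below may be only part of what the source reports. "The series", "measured", "known", "first", "only" and "open" are said of these compounds alone.

Going by the values given here, in a functional assay (muscle tissue) with Cavia porcellus as the target (a lower number here means that less compound is needed, a higher number that more compound is needed for the effect), compound 3 `COC(=O)C1=C(C)N=C(C)/C(=C(\O)OC)C1c1cccc(OC(C)=O)c1` gives 6030 nM, the highest of the three numbers so far, compared with compound 1 `COC(=O)C1=C(C)N=C(C)/C(=C(\O)OC)C1c1cccc(O)c1` at 1000 nM and compound 2 `COC(=O)C1=C(C)N=C(C)/C(=C(\O)OC)C1c1cccc(Br)c1` at 1.29 nM. Compound 4 `COC(=O)C1=C(C)N=C(C)/C(=C(\O)OC)C1c1cccc(OC(=O)c2ccccc2)c1` has phenyl in place of methyl on a carbonyl carbon, turning acetoxy into benzoyloxy: phenyl in place of methyl on a carbonyl carbon. Among the compounds with values here, no measured step makes this swap. The closest is the modest step that adds acetyl to the oxygen, a 6.0-fold higher number from compound 1 to compound 3 (0.78 log units; beyond the scatter). The large replacement of bromo, a 4700-fold higher number from compound 2 to compound 3 (3.67 log units; beyond the scatter), bears on it less. Neither shows how methyl and phenyl compare, so no change beyond the scatter is expected, and the expected step is a 1.5-fold lower number from compound 3 to compound 4 (0.18 log units; within the scatter). In this assay, compound 4 is estimated at 4000 nM, with a range from 500 nM to 20000 nM.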

Compound 4, half-maximal effective concentration: 6310 nM
Estimate against measurement, compound 4: 1.6-fold (0.20 log units) below, within the range that was stated.
By their numbers in this assay, from the lowest: compound 2; then compound 1; then compounds 3 and 4 (each within the scatter of the next).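

In this assay, phenyl in place of methyl on the carbonyl carbon gives a 1.0-fold higher number from compound 3 to compound 4 (0.02 log units; within the scatter), so acetoxy and benzoyloxy cannot be told apart here. Both acylated compounds also sit on the same side of the hydroxy compound, with benzoyl on the oxygen giving a 6.3-fold higher number from compound 1 to compound 4 (0.80 log units; beyond the scatter), and benzoyloxy remains far from bromo, at a 4900-fold higher number from compound 2 to compound 4 (3.69 log units; beyond the scatter). No measurement shown here explains these results. On these data alone, whether an amine or a carboxylic acid on this aromatic carbon would approach the bromo value remains open, as does the effect of a longer chain on the carbonyl carbon.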